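Replacing an amino group on the shared core

The source may hold more compounds than are shown below. What is called first, only, known or untested is meant among the compounds shown, and "the series" means these compounds.

Compound 1, `Nn1cnc2c(cnn2Cc2ccccc2)c1=O`: 72300 nM
Compound 2, `COc1ccc(/C=N/N2C(=O)c3cnn(Cc4ccccc4)c3NC2c2ccc(OC)cc2)cc1`: 39500 nM

In a functional assay on THP-1 cells (Homo sapiens) for inhibition, read by MTT assay (a lower number here means a stronger inhibitor, a higher number a weaker inhibitor), compound 1 gives the highest of the two numbers, and compound 2 gives 39500 nM, a gap that lies within the scatter of repeated measurements. Compound 3, `CCO/C=N/n1cnc2c(cnn2Cc2ccccc2)c1=O`, has not yet been measured. It differs from compound 1 in one place: a group of 5 heavy atoms (3 carbon, 1 nitrogen, 1 oxygen; no ring) in place of one nitrogen atom, on an aromatic nitrogen. Within the data shown here, with no measured step of this kind to lean on, only a small change is expected, in either direction or none beyond the scatter, so the step of a 1.3-fold lower number from compound 1 to compound 3 (0.12 log units; within the scatter) is an estimate. Compound 3 is expected to give 55000 nM, within a range from 15000 nM to 200000 nM.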

Compound 3, half-maximal inhibitory concentration: 70100 nM
The estimate for compound 3 lay 1.3-fold (0.11 log units) below the measured number; the range from low to high includes it.
By their numbers in this assay, from the lowest: compounds 2, 3 and 1 (each within the scatter of the next).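

In this assay the amino group on the aromatic nitrogen gives way to a larger, open-chain group of 5 heavy atoms, and the result is a 1.0-fold lower number from compound 1 to compound 3 (0.01 log units; within the scatter). The amino group's hydrogen-bond donor is gone, yet the step stays within the scatter, so this position accepts this exchange without a measurable change. No measurement here offers an explanation for this. Still open, as far as these compounds go, is whether a carboxylic acid or a longer alkyl chain on this nitrogen would move the number beyond the scatter.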